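Swapping phenyl for bromopyridinyl on the urea of compound 3

The source may hold more compounds than are shown below. What is called first, only, known or untested is meant among the compounds shown, and "the series" means these compounds.

Compound 1, `O=C(Nc1ccc2ccccc2c1)NC1CCN(C/C2=C/CCCCCC2)CC1`: 110 nM
Compound 2, `O=C(Nc1cc(F)cc(C(F)(F)F)c1)NC1CCN(C/C2=C/CCCCCC2)CC1`: 47 nM
Compound 3, `CC1(C)[C@H]2CC=C(CN3CCC(NC(=O)Nc4ccccc4)CC3)[C@@H]1C2`: 2000 nM

All three compounds share a urea linked to a piperidine, and each was tested in a functional assay on CHO cells for antagonist activity at C-X-C chemokine receptor type 3 (Homo sapiens), read by GTPgammaS binding; on this read-out higher numbers stand for weaker inhibition and lower numbers for stronger inhibition. Compound 1 gives 110 nM and compound 2 gives 47 nM, while compound 3 gives 2000 nM. Compound 3 thus stands at the highest number of the three, that is, the weakest inhibition, well apart from both others and furthest from compound 2. No two of these compounds differ in only one place, so the numbers can be read side by side but not as single steps.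

Compound 4, `CC1(C)[C@H]2CC=C(CN3CCC(NC(=O)Nc4cncc(Br)c4)CC3)[C@@H]1C2`, keeps the core of compound 3 and changes only the aromatic group on the urea: 5-bromopyridin-3-yl in place of phenyl on an amide-type nitrogen. Going by the values given here, the only guide is that compound 2, which carries fluorine and trifluoromethyl on its aromatic ring, gives the lowest number, whereas compound 3 with plain phenyl gives the highest. On that basis a moderate move toward stronger inhibition is expected, of a size a 2.5-fold lower number from compound 3 to compound 4 (0.40 log units; beyond the scatter), though it could also stay within the scatter. Compound 4 is estimated at 800 nM in this assay, with a likely range from 250 nM to 2500 nM.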

Compound 4, inhibition constant: 171 nM
Estimate against measurement, compound 4: 4.7-fold (0.67 log units) above, and the stated range ends above it.
By their numbers in this assay, from the lowest: compound 2; then compounds 1 and 4 (each within the scatter of the next); then compound 3.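

With the core of compound 3 held fixed, the aromatic group on the urea has a large influence on the result in this assay: 5-bromopyridin-3-yl in place of phenyl on the amide-type nitrogen gives a 12-fold lower number from compound 3 to compound 4 (1.07 log units; beyond the scatter). Going by these compounds alone, this is the first comparison here in which only one part of the molecule differs, so the change in number can be assigned to this group swap rather than to a mixture of differences, as it could not among the earlier compounds. The swap brings in a ring nitrogen, which adds a hydrogen-bond acceptor, and a bromine together, and nothing available here explains why the number falls.

Going by these compounds, a pyridinyl ring without the bromine and a phenyl ring carrying bromine, each on the same core, would be needed to tell the two parts of the change apart, so it remains open whether one of them or the pair accounts for the step. Also open, on these data alone, is whether chlorine, a nitrile or an amine in place of the bromine would keep the number as low.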